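The source may report more compounds than this note shows. Statements on the series, on what has been measured and on what is new or still open speak of the compounds shown alone.

Measured compounds in a functional assay on A549 cells (Homo sapiens) for antiproliferative activity, read by MTT assay, with a stated time of 72 h; on this read-out higher numbers stand for weaker inhibition and lower numbers for stronger inhibition:
- compound 1, `COc1cc(-n2cnc3ccc(-c4ccc(C)cc4F)cc32)cc(OC)c1OC`, gives > 10000 nM.
- compound 2, `COc1cc(-n2cnc3ccc(-c4cccc(C)c4)cc32)cc(OC)c1OC`, gives 3820 nM.
- compound 3, `COc1cc(-n2cnc3ccc(-c4cccc(N)c4)cc32)cc(OC)c1OC`, gives 640 nM.

Compound 1 is reported by this assay only as a limit, (the limit of > 10000 nM in this assay, at which 1 of the 3 values shown sits), and not as a number; where compound 1 stands is therefore known only as an upper bound on its potency. Compound 4, `COc1cc(-n2cnc3ccc(-c4ccc(Cl)cc4Cl)cc32)cc(OC)c1OC`, differs from compound 1 in one place: 2,4-dichlorophenyl in place of 2-fluoro-4-methylphenyl on an aromatic carbon.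

Two measured steps start from compound 1. Both exchange the whole 2-fluoro-4-methylphenyl and both lower the number: an at least 2.6-fold lower number from compound 1 to compound 2 (0.41 log units; beyond the scatter), and an at least 15-fold lower number from compound 1 to compound 3 (1.19 log units; beyond the scatter); between the two new groups, a 6.0-fold lower number from compound 2 to compound 3 (0.78 log units; beyond the scatter). Neither step tests a 2,4-dichlorophenyl, and the groups that gave the gains in this assay, 3-methylphenyl and 3-aminophenyl, carry a single substituent, whereas the 2,4-dichlorophenyl of compound 4 keeps the two-substituent pattern of compound 1. For the measured compounds named here, no measured step supports a gain for compound 4, and the starting point is itself a limit.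

For compound 4 the expected value in this assay is 12000 nM (range 3500 nM to 40000 nM), which as a step means a step that the limit leaves unreadable from compound 1 to compound 4, most likely reported again as a limit.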

Compound 4, half-maximal inhibitory concentration: > 10000 nM
Compound 4 ended at the assay's limit; the forecaster's own chance of this, stated with the estimate: 65%; the middle value is on the limit's open side.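

In this assay compound 4, like compound 1, is reported only as a limit, so the step between them cannot be read: the limit of > 10000 nM in this assay, at which 2 of the 4 values shown sit.

Replacing either single-substituent group with 2,4-dichlorophenyl at this position costs activity, with an at least 15-fold higher number from compound 3 to compound 4 (1.19 log units; beyond the scatter) and with an at least 2.6-fold higher number from compound 2 to compound 4 (0.41 log units; beyond the scatter). Across the four compounds shown, both phenyl groups with two substituents sit at the limit and both with one substituent give numbers, and no compound goes against this.

Still open, as far as these compounds go, is whether the two-substituent pattern or the identity of the substituents accounts for this split, as a chlorine in place of the methyl of compound 2 would help to show. A hydroxyl in place of the amino of compound 3 would show whether the amino group itself is needed for the lower number.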